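The compounds below may be only part of what the source reports. "The series", "measured", "known", "first", "only" and "open" are said of these compounds alone.

Measured so far:

Compound 1, `O=C(O)CCNC(=O)CN(CCOc1ccc2c(c1)CCC2)S(=O)(=O)c1ccc(Cl)cc1Cl`, gives 410 nM in an assay on WI 38 cells for displacement of a labelled ligand from B1 bradykinin receptor (Homo sapiens); on this read-out higher numbers stand for weaker inhibition and lower numbers for stronger inhibition.
Compound 2, `COc1cc(CN(CC(=O)NCc2ccccc2Cl)S(=O)(=O)c2ccc(CN3CCCCC3)cc2)ccc1OCC(C)C`, gives 34 nM in this assay.
Compound 3, `O=C(O)CCNC(=O)CN(CCOc1ccccc1)S(=O)(=O)c1ccc(Cl)cc1Cl`, gives 13000 nM in this assay.

Compound 2 has the lowest number of the three, and its distance to each of the other two lies beyond the scatter: compound 1 is nearest and compound 3 furthest. Within the data shown here, the only step that can be read between compounds differing in one place is a 32-fold higher number from compound 1 to compound 3 (1.50 log units; beyond the scatter), and it concerns a change on an oxygen on a saturated carbon in a different part of the molecule.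

Compound 4, `COc1cc(CN(CC(=O)NCc2ccccc2Cl)S(=O)(=O)c2ccc(CN(C)C)cc2)ccc1OCC(C)C`, is compound 2 with dimethylamino in place of piperidin-1-yl on a saturated chain carbon bound to an aromatic carbon. Among the measured compounds shown here, no measured pair shows this kind of change, so the one measured step gives no direct guidance on it; the ring that leaves and the group that enters each carry the same single hydrogen-bond acceptor, and no charge is gained or lost. On that basis a step of modest size, if any, is expected, and it is more likely to run toward a higher number than a lower one; the expected step is a 1.8-fold higher number from compound 2 to compound 4 (0.25 log units; within the scatter). The estimate for compound 4 in this assay is therefore 60 nM, with a range from 20 nM to 200 nM.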

Compound 4, inhibition constant: 93 nM
Beside the measured number, compound 4's estimate is 1.6-fold (0.19 log units) below it, within the range that was stated.
By their numbers in this assay, from the lowest: compound 2; then compound 4; then compound 1; then compound 3.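

In this assay, among these compounds, the swap of piperidin-1-yl for dimethylamino on a saturated chain carbon bound to an aromatic carbon gives a 2.7-fold higher number from compound 2 to compound 4 (0.44 log units; beyond the scatter) and is the first measured step at this position, as the only earlier step lay in a different part of the molecule. It shows that this position responds to the group it carries, even though the hydrogen-bond acceptor count stays the same and no charge is gained or lost. It also shows that the ring can be given up and the group cut from 6 heavy atoms to 3 at a modest cost rather than a large one, and nothing measured here accounts for the size or direction of this step.

With only this one pair, the compounds shown leave open whether the ring itself or simply the size of the group matters, which diethylamino or pyrrolidin-1-yl at the same place could help to separate. They also leave open how morpholin-4-yl or a carboxylic acid would fare there, and whether the same swap would give a similar step on a different core.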